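Cytotoxicity notes on a hydroxyethoxymethyl side-chain series

The compounds below may be only part of what the source reports. "The series", "measured", "known", "first", "only" and "open" are said of these compounds alone.

Measured compounds:
Compound 1, `Nc1ncnc2c1ccn2COCCO`. In a functional assay on HFF cells (Homo sapiens) for cytotoxicity (a lower number here means a stronger inhibitor, a higher number a weaker inhibitor), compound 1 gives > 100000 nM, which is a limit of the assay.
Compound 2, `CC(=O)OCCOCn1ccc2c(Cl)nc(Cl)nc21`. In this assay compound 2 gives > 100000 nM, also a limit of the assay.
Compound 3, `OCCOCn1ccc2c(Cl)nc(Cl)nc21`. In this assay compound 3 gives 100000 nM.

Compound 1 therefore stands only at a limit in this assay, with no number of its own; it shares the limit of > 100000 nM in this assay, at which 2 of the 3 values shown sit, with compound 2. Within the data shown here, the single measured step, a number no higher from compound 2 to compound 3 (the limit leaves the size open), hydrogen in place of acetyl on an oxygen on a saturated carbon, concerns the side chain and its size cannot be read, since one end of it is a limit.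

Compound 4, `Nc1nc(N)c2ccn(COCCO)c2n1`, is not yet measured. It differs from compound 1 by amino in place of hydrogen on an aromatic carbon. Among the measured compounds shown here, no measured step touches this position, so nothing speaks for a change in this assay beyond the scatter. For compound 4 the step of a number no higher from compound 1 to compound 4 (the limit leaves the size open) is expected to be none beyond the scatter. Compound 4 is estimated at 100000 nM, within 50000 nM to 200000 nM, and most likely the assay will again report only a limit.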

Compound 4, half-maximal inhibitory concentration: > 100000 nM
Compound 4: no number, only a limit; the forecaster's own chance of this, stated with the estimate: 80%; the middle value sits exactly at the limit.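

Compound 1 and compound 4 yield no new readable step, each standing only at the same limit of the assay: the limit of > 100000 nM in this assay, at which 3 of the 4 values shown sit.

The compounds shown leave open whether amino in place of hydrogen on an aromatic carbon changes the value in this assay at all, and in which direction or by how much.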